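This account rests on a few compounds, and the source may have more. Where it says the series, first, only, none or still open, it means among the compounds named here.

Compound 1 `Cn1c(/C=C/C(=O)c2ccccc2O)cc(Br)c1Br` and compound 2 `O=C(/C=C/c1cc(Br)c(Br)[nH]1)c1ccccc1O` share one core and differ in a single place: hydrogen in place of methyl on an aromatic nitrogen. In a functional assay on MCF7 cells (Homo sapiens) for cytotoxicity, read by MTT assay, with stated times of 6 h and 48 h (on this read-out higher numbers stand for weaker inhibition and lower numbers for stronger inhibition), compound 1 gives 2510 nM. In this assay compound 2 gives 1490 nM, so the change made a 1.7-fold lower number from compound 1 to compound 2 (0.23 log units; within the scatter). Compound 3 `Cn1c(-c2cc(-c3ccc[nH]3)no2)cc(Br)c1Br` carries a different core; the difference between the two cores is not broken down here. For compound 3 this assay reports only a limit, >= 100000 nM, which is the limit of >= 100000 nM in this assay, at which 1 of the 3 values shown sits. Compound 4 `Brc1cc(-c2cc(-c3ccc[nH]3)no2)[nH]c1Br` has not yet been measured in this assay. It differs from compound 3 by the same change that separates compound 1 from compound 2: hydrogen in place of methyl on an aromatic nitrogen. Because the earlier pair showed a 1.7-fold lower number from compound 1 to compound 2 (0.23 log units; within the scatter), the same change is expected to shift very little here, and the step estimated is a number no higher from compound 3 to compound 4 (the limit leaves the size open). Compound 4 is therefore expected to sit near the limit of the measurement again, with an estimated value of 100000 nM, between 30000 nM and 300000 nM. What this assay actually reports for compound 4 remains to be seen.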

Compound 4, half-maximal inhibitory concentration: >= 100000 nM
Compound 4: a limit, no number; the forecaster's own chance of this, stated with the estimate: 80%; the middle value lies on the limit itself.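

Compound 3 and compound 4 both end at a limit rather than a number in this assay, so the step between them cannot be read: the limit of >= 100000 nM in this assay, at which 2 of the 4 values shown sit.

The compounds shown leave open whether hydrogen in place of methyl on the aromatic nitrogen changes anything on the core of compound 3, and what real values lie behind these limits.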